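A few compounds are considered here, and "the series" means these few. Any claim that something is new, unique, unknown or untested is made for them only; others in the source may bear on it.

Measured so far in a physicochemical assay for acid dissociation, read by spectrophotometry:
Compound 1 `CCOc1cc(CN2CCC(NC(=O)c3ccc(NC)nc3)CC2)cc(OCC)c1F` gives 7.83
Compound 2 `CCOc1cc(CN2CCCC(NC(=O)c3ccc(N)nc3)CC2)cc(F)c1F` gives "not determined" (no result reported)

For the measured compounds named here, compound 1 holds the only number in this small set. Compound 2 has no reported result, so compound 1 cannot yet be ranked against anything.

Compound 3 `CCOc1cc(CN2CCC(NC(=O)c3ccc(NC)nc3)CC2)cc(OCC)c1-c1ccc(F)cc1` awaits measurement in this assay and differs from compound 1 in one place, described by 4-fluorophenyl in place of fluoro on an aromatic carbon while the rest of the structure stays the same. The 4-fluorophenyl stands on an aromatic carbon, ortho to two ethoxy groups and para to a large group.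

Going by the values given here, no measured pair here shows a step of this kind, so the data offer no precedent for its size. Starting from compound 1 at 7.83 no change beyond the scatter is expected, in either direction. The expected result is a number 0.03 log units lower from compound 1 to compound 3 (within the scatter) in this estimate. The estimated value for compound 3 is 7.8 with an expected range from 7.4 to 8.2 in this assay for this measurement.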

Compound 3, acid dissociation constant: 7.86
Compound 3: middle estimate off by 0.06 log units, on the low side, and the stated range covers the measured number.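

In this assay, for the compounds shown here, putting 4-fluorophenyl in place of fluoro on the aromatic carbon ortho to two ethoxy groups gives a number 0.03 log units higher from compound 1 to compound 3 (within the scatter), the first step in this set that can be read. It shows that at this position, a group of 7 heavy atoms with its own six-membered aromatic ring can stand where a single fluoro stood, and the two compounds cannot be told apart by this read-out. No measurement shown here explains this result.

The compounds shown leave open whether the read-out would stay the same with a carboxylic acid or a dimethylamino group on this carbon. They also leave open whether 4-fluorophenyl would behave the same way on a core other than that of compound 1.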